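Same atoms, joined differently: from compound 2 to compound 3

A few compounds are considered here, and "the series" means these few. Any claim that something is new, unique, unknown or untested is made for them only; others in the source may bear on it.

- compound 1 `O=C(O)C1CCN(CCCOc2ccc3[nH]c(-c4cc5ccccc5nc4O)cc3c2)CC1` with 7.7 mL/min/kg
- compound 2 `NC1CCN(C(=O)c2ccc3[nH]c(-c4cc5ccccc5nc4O)cc3c2)C1` with 26 mL/min/kg

Going by the values given here, both numbers come from an in vivo ADME assay on the whole organism (plasma) for pharmacokinetics, with Canis familiaris (Canis lupus familiaris) as the target (on this read-out higher numbers stand for fast clearance and lower numbers for slow clearance), and they are the only measurements available so far. Compound 2 holds the higher of the two, and its distance from compound 1 lies beyond the usual scatter. The two measured compounds are not a single-change pair, so their gap says nothing direct about the next compound.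

That next compound is compound 3 `O=C(NC1CCNC1)c1ccc2[nH]c(-c3cc4ccccc4nc3O)cc2c1` which has the same atoms as compound 2, joined differently. It carries (pyrrolidin-3-yl)amino in place of 3-aminopyrrolidin-1-yl on a carbonyl carbon. Among the compounds with values here, no measured pair shows a change of this kind, so the size of the step in this assay cannot be read from the data. The closest reference is compound 2 at 26 mL/min/kg and no step beyond the scatter is expected from it. The expected change is a 1.2-fold lower number from compound 2 to compound 3 (0.07 log units; within the scatter) in this read-out. Compound 3 is estimated at 22 mL/min/kg within an expected range of 10 mL/min/kg to 48 mL/min/kg once it is measured.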

Compound 3, clearance: 38 mL/min/kg
Compound 3: the middle estimate sits 1.7-fold (0.24 log units) below what was measured; measured number inside the range.
By their numbers in this assay, from the lowest: compound 1; then compounds 2 and 3 (each within the scatter of the next).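

Going by these compounds alone, compound 2 and compound 3 give the first single-place comparison, and in this assay exchanging 3-aminopyrrolidin-1-yl for (pyrrolidin-3-yl)amino on a carbonyl carbon gives a 1.5-fold higher number from compound 2 to compound 3 (0.16 log units; within the scatter). At this position, then, the read-out does not separate the two ways of joining the same atoms, even though the two groups differ in their count of hydrogen-bond donors, and compound 2 and compound 3 cannot be ranked against each other. No measurement is available that would account for the size of this step.

The compounds shown leave open whether a differently built group on the same carbonyl carbon, such as (piperidin-4-yl)amino, a dimethylamino group or a group ending in a carboxylic acid, would move the clearance beyond the scatter. Compound 2 and compound 3 differ from compound 1 in more than one place, so the lower number of compound 1 at 7.7 mL/min/kg cannot be assigned to its carboxylic acid, its chain or any other single feature.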